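EZH2 Y641N series: ring-bearing side chain revisited

A few compounds are considered here, and "the series" means these few. Any claim that something is new, unique, unknown or untested is made for them only; others in the source may bear on it.

Measured so far:
Compound 1 `Cc1cc(C)c(CN2CCc3c(Cl)cc([C@@H](CO)[C@@H]4CCOC4)c(Cl)c3C2=O)c(=O)[nH]1` — 1260 nM
Compound 2 `Cc1cc(C)c(CN2CCc3c(Cl)cc(-c4c(C)noc4C)c(Cl)c3C2=O)c(=O)[nH]1` — 1.15 nM
Compound 3 `Cc1cc(C)c(CN2CCc3c(Cl)cc([C@H](C)CO)c(Cl)c3C2=O)c(=O)[nH]1` — 17 nM

In an assay for inhibition of histone-lysine N-methyltransferase EZH2 variant Y641N (Homo sapiens), read by scintillation counting, with a stated time of 60 min, in the presence of a further agent that is not named here (a lower number here means a stronger inhibitor, a higher number a weaker inhibitor), compound 3 gives 17 nM, the second highest of the three numbers. Its nearest neighbour is compound 2, with a 15-fold higher number from compound 2 to compound 3 (1.17 log units; beyond the scatter); its furthest is compound 1, with a 74-fold lower number from compound 1 to compound 3 (1.87 log units; beyond the scatter).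

Compound 4 `Cc1cc(C)c(CN2CCc3c(Cl)cc([C@H](CO)[C@H]4CCCO4)c(Cl)c3C2=O)c(=O)[nH]1` is not yet measured. Relative to compound 3 the change is a group of 8 heavy atoms (6 carbon, 2 oxygen; one five-membered non-aromatic ring with 1 hetero atom) in place of a group of 4 heavy atoms (3 carbon, 1 oxygen; no ring), on an aromatic carbon. Within the data shown here, the one measured step that speaks to this is the one from compound 1 to compound 3, where removing a five-membered non-aromatic ring from the same chain carbon produced a 74-fold lower number from compound 1 to compound 3 (1.87 log units; beyond the scatter). Compound 4 reintroduces a ring of the same size and hetero atom count, attached at a different ring carbon, so the step from compound 3 to compound 4 is expected to run the other way and to be large, though the different attachment point leaves the exact size uncertain. The step from compound 1 to compound 2 concerns the aromatic replacement and does not bear directly here.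

For compound 4 the expected step is a 35-fold higher number from compound 3 to compound 4 (1.55 log units; beyond the scatter), giving an estimate of 600 nM, within a range of 200 nM to 2000 nM.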

Compound 4, inhibition constant in the histone-lysine N-methyltransferase EZH2 assay: 8 nM
The estimate for compound 4 lay 75-fold (1.88 log units) above the measured number, and the stated range ends above it.
By their numbers in the histone-lysine N-methyltransferase EZH2 assay, from the lowest: compound 2; then compound 4; then compound 3; then compound 1.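

In the histone-lysine N-methyltransferase EZH2 assay, a five-membered non-aromatic ring on this side chain is compatible with a low number, with a 2.1-fold lower number from compound 3 to compound 4 (0.33 log units; beyond the scatter), so the weak result for compound 1 does not follow from the presence of such a ring alone. The two ring-bearing groups have the same heavy-atom count and composition yet give a 160-fold lower number from compound 1 to compound 4 (2.20 log units; beyond the scatter), which shows that this position is sensitive to how the ring is attached and oriented, while the 3,5-dimethyl-1,2-oxazol-4-yl group keeps its advantage, with a 7.0-fold higher number from compound 2 to compound 4 (0.84 log units; beyond the scatter). In a physicochemical assay for solubility, measured as kinetic solubility (a lower number here means a less soluble compound, a higher number a more soluble compound), compound 3 gives 131000 nM and compound 4 gives 430000 nM, so the larger group brings no loss of solubility at this position: the measured solubility of compound 3, 131000 nM, and of compound 4, 430000 nM, a 3.3-fold higher number (0.52 log units; beyond the scatter)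

The ring attachment point and the defined stereocentres change together between compound 1 and compound 4, so the compounds shown cannot separate their contributions. On these data alone, it also remains open whether a ring bearing an amine, such as a piperidine, or a carboxylic acid on the same chain carbon would keep the number near that of compound 4.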